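Benzyloxycarbonyl for isobutoxycarbonyl across two cores

A few compounds are considered here, and "the series" means these few. Any claim that something is new, unique, unknown or untested is made for them only; others in the source may bear on it.

Measured compounds:
compound 1, `Cc1c(Oc2ccc(/C=C3\SC(=O)NC3=O)cc2)ncnc1OC1CCN(C(=O)OCC(C)C)CC1`: 70.2%
compound 2, `Cc1c(Oc2ccc(/C=C3\SC(=O)NC3=O)cc2)ncnc1OC1CCN(C(=O)OCc2ccccc2)CC1`: 43.3%
compound 3, `CC(C)COC(=O)N1CCC(Oc2cc(Oc3cccc(/C=C4\SC(=O)NC4=O)c3)ncn2)CC1`: 62.4%

All three were run in a functional assay on CHO-K1 cells for agonist activity at Glucose-dependent insulinotropic receptor (Homo sapiens), read by cAMP accumulation and immunoassay, with a stated time of 1 h; on this read-out lower numbers stand for smaller maximal responses and higher numbers for larger maximal responses. Compound 1 and compound 2 share one core and differ by a single change, (phenyl in place of isopropyl on a saturated chain carbon bound to an oxygen next to a carbonyl group), which gave a number 26.9 percentage points lower from compound 1 to compound 2 (beyond the scatter). Compound 3 sits on a second core; the difference between the two cores is not broken down here. Its value stands within the scatter of compound 1 and beyond the scatter of compound 2.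

Compound 4, `O=C1NC(=O)/C(=C/c2cccc(Oc3cc(OC4CCN(C(=O)OCc5ccccc5)CC4)ncn3)c2)S1`, is not yet measured. It carries the same change relative to compound 3, (phenyl in place of isopropyl on a saturated chain carbon bound to an oxygen next to a carbonyl group), on the same place as in the measured pair. The only basis for an expectation is the one measured step, so a step of similar size is expected: a number 25.4 percentage points lower from compound 3 to compound 4 (beyond the scatter), resting on compound 1 to compound 2 having shown a number 26.9 percentage points lower from compound 1 to compound 2 (beyond the scatter). On that basis compound 4 is estimated at 37% in this assay, with a range from 22% to 55%, the width reflecting that the change has been seen only once and on a different core.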

Compound 4, largest response reached (Emax), in percent of the reference or control that the assay uses: 98.3%
Compound 4: the middle estimate sits 61.3 percentage points below what was measured; measured number above the stated range.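

On the second core, phenyl in place of isopropyl gives a number 35.9 percentage points higher from compound 3 to compound 4 (beyond the scatter), so in this assay the same change moves the maximal response in opposite directions on the two cores: the same change on two cores in this assay, a number 26.9 percentage points lower (beyond the scatter) from compound 1 to compound 2 and a number 35.9 percentage points higher (beyond the scatter) from compound 3 to compound 4, 62.8 percentage points apart, beyond the scatter of two such steps

A step measured on one core therefore cannot be carried to the other in this series, in size or in direction. This rests on one matched pair per core and does not show which part of the core difference governs the reversal, nor does it give a rule for any compound beyond these four.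

Going by these compounds, it remains open whether the reversal is specific to the phenyl group or would also appear with a cyclohexyl group or a longer chain at the same place. Also open, on these data alone, is how an amine or a carboxylic acid on that phenyl would behave on each core.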